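The source may hold more compounds than are shown below. What is called first, only, known or untested is meant among the compounds shown, and "the series" means these compounds.

In a functional assay on A-375 cells (Homo sapiens) for antiproliferative activity, read by CCK-8 assay, with a stated time of 72 h (on this read-out lower numbers stand for stronger inhibition and higher numbers for weaker inhibition), compound 1 (`CCC(C)n1cnc2c(NCc3ccc(C(=O)Nc4ccccc4N)cc3)nc(Cl)nc21`) gives 2880 nM and compound 3 (`Nc1ccccc1NC(=O)c1ccc(COCNc2nc(Nc3ccccc3)c3ncn(C4CCCC4)c3n2)cc1`) gives 8700 nM. Compound 2 (`Cc1ccc(Nc2nc(Cl)nc3c2ncn3Cc2ccc(C(=O)Nc3ccccc3N)cc2)cc1`) gives 470 nM, the lowest of the three numbers and beyond the scatter of both others. Compound 4 (`Nc1ccccc1NC(=O)c1ccc(Cn2cnc3c(Nc4cccc(Cl)c4)nc(Cl)nc32)cc1`) differs from compound 2 in one place: 3-chlorophenyl in place of 4-methylphenyl on a nitrogen on an aromatic ring. For the measured compounds named here, no measured pair shows a change of this kind, so the data offer no direct guide. The expectation therefore starts from compound 2 at 470 nM, and no shift beyond the scatter is expected in this assay. The estimated change is small, a 1.2-fold lower number from compound 2 to compound 4 (0.09 log units; within the scatter). The expected value for compound 4 is 380 nM, with an estimated range of 130 nM to 1100 nM.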

Compound 4, half-maximal inhibitory concentration: 6080 nM
The estimate for compound 4 lay 16-fold (1.20 log units) below the measured number; the whole stated range lies below it.
By their numbers in this assay, from the lowest: compound 2; then compound 1; then compounds 4 and 3 (each within the scatter of the next).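

In this assay the group on this nitrogen proves far from interchangeable: 3-chlorophenyl in place of 4-methylphenyl gives a 13-fold higher number from compound 2 to compound 4 (1.11 log units; beyond the scatter) even though both groups have the same number of heavy atoms and one six-membered aromatic ring of carbon only. For the compounds shown here, the earlier compounds offered no step at this place, so this is the first direct reading of it. Nothing measured here speaks to the cause of this step. As far as these compounds go, what stays open is whether the chlorine or its place on the ring carries the step, which 4-chlorophenyl or 3-methylphenyl on the same nitrogen would help separate. Also open, from the compounds shown here alone, is how a phenyl ring bearing an amine or a carboxylic acid would read there.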